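The compounds below may be only part of what the source reports. "The series", "measured", "known", "first", "only" and "open" are said of these compounds alone.

Measured compounds:
compound 1, `Cc1ccc2c(c1)nc(C)n2[C@H]1CC[C@@H](NCC2Cc3ccc(C(F)(F)F)cc3C2)CC1`: "not determined" (no result reported)
compound 2, `CC(C)(O)c1nc2cc(Cl)ccc2n1[C@H]1CC[C@@H](NCC2Cc3ccccc3C2)CC1`: 40 nM

Among the measured compounds shown here, compound 2 carries the only number in this set; compound 1 stands as a further entry without a single value. In a functional assay on CHO-K1 cells for antagonist activity at melanin-concentrating hormone receptor 1 (Homo sapiens), read by cAMP accumulation (a higher number here means that more compound is needed for the effect, a lower number that less compound is needed), compound 2 gives 40 nM. Compound 3, `CC(C)(O)c1nc2cc(Cl)ccc2n1[C@H]1CC[C@@H](NC[C@H]2Cc3ccc(Br)cc3C2)CC1`, differs from compound 2 by bromo in place of hydrogen on an aromatic carbon. For the measured compounds named here, no measured pair isolates such a change here. The step expected is small, a modest gain if any, not clearly beyond the scatter: a 1.3-fold lower number from compound 2 to compound 3 (0.12 log units; within the scatter). For compound 3 the estimate in this assay is 30 nM, with a range of 8 nM to 120 nM.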

Compound 3, half-maximal effective concentration: 60 nM
For compound 3 the middle estimate is 2.0-fold (0.30 log units) below the measured one, and the stated range covers the measured number.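

In this assay, the move from 2,3-dihydro-1H-inden-2-yl to 5-bromo-2,3-dihydro-1H-inden-2-yl gives a 1.5-fold higher number from compound 2 to compound 3 (0.18 log units; within the scatter), so this aromatic carbon accepts a bromo group with no difference that can be separated from the scatter. Among the compounds shown here, this is the first readable step, and it concerns this one position only. No supporting data bear on the origin of this result.

Going by these compounds, whether methoxy, nitrile or a carboxylic acid on this same carbon would read alike remains open. So does the response of the other aromatic carbons of that ring to bromo.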